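The compounds below may be only part of what the source reports. "The series", "measured", "known", "first", "only" and "open" are said of these compounds alone.

Of the compounds shown here, two have been measured so far in an assay on isolated protein for inhibition of Long-chain-fatty-acid--CoA ligase 1 (Homo sapiens), read by mass spectrometry, with a stated time of 90 min, in the presence of a further agent that is not named here; on this read-out higher numbers stand for weaker inhibition and lower numbers for stronger inhibition. Compound 1, `Cc1cccc(Oc2nc3cc(O[C@H]4CC[C@@H](C(=O)O)CC4)ccc3n2C)c1`, gives 78000 nM in this assay. For the measured compounds named here, compound 2, `Cc1cccc(Cc2nc3cc(O[C@H]4CC[C@@H](C(N)=O)CC4)ccc3n2C)c1`, gives 950 nM in this assay, the lower of the two numbers; compound 1 is the only neighbour, and the gap between the two lies well beyond the scatter of repeated measurements. Compound 1 and compound 2 differ in more than one place, so no single-change step can be read from them.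

Compound 3, `Cc1cccc(Cc2nc3cc(O[C@H]4CC[C@@H](c5noc(=O)[nH]5)CC4)ccc3n2C)c1`, is the next compound, and it has not yet been measured. It departs from compound 2 as follows: a group of 6 heavy atoms (2 carbon, 2 nitrogen, 2 oxygen; one five-membered aromatic ring with 3 hetero atoms) in place of a group of 3 heavy atoms (1 carbon, 1 nitrogen, 1 oxygen; no ring), on a saturated ring carbon. Going by the values given here, no measured pair shows this particular change, so the size of the step is open. Because the amide group of compound 2 returns 950 nM and the remainder of the molecule is kept, compound 3 is expected to stay in the same general region, with a modest shift of a 1.6-fold higher number from compound 2 to compound 3 (0.20 log units; within the scatter) that may fall either side of no change. The estimate for compound 3 in this assay is therefore 1500 nM, in a range from 300 nM to 8000 nM.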

Compound 3, half-maximal inhibitory concentration: 47 nM
For compound 3 the middle estimate is 32-fold (1.50 log units) above the measured one; measured number outside the range, below it.
By their numbers in this assay, from the lowest: compound 3; then compound 2; then compound 1.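

In this assay, replacing the carbamoyl group with the five-membered aromatic ring with 3 hetero atoms, on this saturated ring carbon, gives a 20-fold lower number from compound 2 to compound 3 (1.31 log units; beyond the scatter), a large change that lies beyond the scatter. For the compounds shown here, this is the first single-change step, and it shows that the group at this position can strongly affect the number even when the rest of the molecule stays the same, which the earlier pair could not show because its compounds differ in more than one place. The two groups have the same count of hydrogen-bond donors, while the entering group is larger, contains a ring and has more hydrogen-bond acceptors, but no measurement here explains why the number falls.

On these data alone, a single step cannot separate the contributions of ring, size and acceptor count, so it remains open which of these differences matters. As far as these compounds go, it also remains open how other groups on the same carbon, such as a tetrazole ring, a nitrile or an amine, would compare with the carbamoyl group and the five-membered ring.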